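Acid to Anilide on a Shared Vinyl-Dihydrofuran Core

The source may report more compounds than this note shows. Statements on the series, on what has been measured and on what is new or still open speak of the compounds shown alone.

The study examines a small family sharing one core, read in a functional assay on HeLa cells (Homo sapiens) for cytotoxicity, read by MTT assay, with a stated time of 24 h; on this read-out higher numbers stand for weaker inhibition and lower numbers for stronger inhibition. Compound 1, `C=CC1=C(C(=O)NCc2ccccc2)C(c2ccc(OC)c(OC)c2)OC1`, gives only a limit of the assay, > 100000 nM. Compound 3, `C=CC1=C(C(=O)NCCCCC)C(c2ccc(Cl)c(Cl)c2)OC1`, likewise reaches only a limit, > 100000 nM. Within the data shown here, compound 2, `C=CC1=C(C(=O)O)C(c2ccc(F)cc2)OC1`, is the one member with a number: in this assay compound 2 gives 67400 nM. It stands as the only number shown; where the other two values sit is told in the limit of > 100000 nM in this assay, at which 2 of the 3 values shown sit.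

Compound 4, `C=CC1=C(C(=O)Nc2ccccc2)C(c2ccc(F)cc2)OC1`, has not yet been measured in this assay. It differs from compound 2 at one place: anilino in place of hydroxy on a carbonyl carbon. Among the measured compounds shown here, no step between two measured compounds is available, so the direction of this change rests on what the three measured compounds show, and both amide-bearing members sit at the limit described in the limit of > 100000 nM in this assay, at which 2 of the 3 values shown sit.

On that basis the step is expected to run from compound 2 toward weaker inhibition, by about a 1.5-fold higher number from compound 2 to compound 4 (0.17 log units; within the scatter). Compound 4 is accordingly estimated at 100000 nM in this assay, within a range from 45000 nM to 220000 nM, with a real chance that only a limit is reported.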

Compound 4, half-maximal inhibitory concentration: > 100000 nM
Compound 4 ended at the assay's limit (the forecaster's own chance of this, stated with the estimate: 55%); the middle value sits exactly at the limit.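

In this assay, among these compounds, the change to anilino in place of hydroxy on a carbonyl carbon gives the first step that can be read between two measured compounds: an at least 1.4-fold higher number from compound 2 to compound 4 (0.17 log units; that floor lies within the scatter). From the compounds shown here alone, compound 4 carries only a limit, > 100000 nM, so this step gives a floor and not a size, and its true extent remains unknown. Compound 4 keeps everything else of compound 2, so the anilino amide's place at the limit appears here with no other change on the shared core, and the only number in the set stays with the hydroxy compound: the limit of > 100000 nM in this assay, at which 3 of the 4 values shown sit.

Going by these compounds, whether a methyl ester or a primary amide on this carbonyl carbon would give a number, as compound 2 does, stays open, as does how far compound 4 lies past the limit. Among the compounds shown here, also open is whether the carboxylic acid would still give a number with the aryl groups of compound 1 or compound 3 in place of the one carried by compound 2.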